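This account rests on a few compounds, and the source may have more. Where it says the series, first, only, none or still open, it means among the compounds named here.

Measured so far:
- compound 1 `Brc1cccc(CSc2nnc(-c3cnccn3)n2-c2ccccc2)c1`: 18300 nM
- compound 2 `Clc1ccc(CSc2nnc(-c3cnccn3)n2-c2ccccc2)cc1`: 27700 nM
- compound 3 `Brc1ccc(CSc2nnc(-c3cnccn3)n2-c2ccccc2)cc1`: 19800 nM

In a functional assay on BGC-823 cells (Homo sapiens) for antiproliferative activity, read by MTT assay, with a stated time of 48 h (on this read-out lower numbers stand for stronger inhibition and higher numbers for weaker inhibition), compound 3, at 19800 nM, lies within the scatter of both compound 1 and compound 2. Compound 4 `c1ccc(CSc2nnc(-c3cnccn3)n2-c2ccccc2)cc1` has hydrogen in place of bromo on an aromatic carbon, para to a large group: hydrogen in place of bromo on an aromatic carbon. Among the measured compounds shown here, no measured compound lacks the bromo or chloro group, so no measured step covers this removal directly. The nearest evidence is small: a 1.4-fold lower number from compound 2 to compound 3 (0.15 log units; within the scatter), and a 1.1-fold higher number from compound 1 to compound 3 (0.03 log units; within the scatter). No step beyond the scatter is therefore expected in this assay, and no firm direction. The estimated step is a 1.3-fold higher number from compound 3 to compound 4 (0.10 log units; within the scatter). For compound 4 the expected value is 25000 nM, with an estimated range of 12000 nM to 50000 nM.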

Compound 4, half-maximal inhibitory concentration: > 50000 nM
Compound 4: only a limit was reported; the forecaster's own chance of this, stated with the estimate: 10%; middle value at least 2.0-fold (0.30 log units) away from the limit.
By their numbers in this assay, from the lowest: compounds 1, 3 and 2 (each within the scatter of the next). At a limit, above all of these: compound 4.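

In this assay compound 4 gives > 50000 nM as a limit of the assay. Hydrogen in place of bromo gives an at least 2.5-fold higher number from compound 3 to compound 4 (0.40 log units; beyond the scatter) and an at least 2.7-fold higher number from compound 1 to compound 4 (0.43 log units; beyond the scatter) so a substituent on this aromatic carbon matters, although exchanges among the bromo and chloro compounds stayed within the scatter. Hydrogen in place of chloro gives an at least 1.8-fold higher number from compound 2 to compound 4 (0.25 log units; that floor lies within the scatter) and so does not yet separate compound 2 from compound 4. As far as these compounds go, the full size of these steps stays open because compound 4 stands at a limit: the limit of > 50000 nM in this assay, at which 1 of the 4 values shown sits. From the compounds shown here alone, whether a methoxy group or an amine at this place would hold the activity also remains open.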